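The compounds below may be only part of what the source reports. "The series", "measured", "known", "first", "only" and "open" are said of these compounds alone.

Three compounds built on a shared core were measured in an ADME assay on microsomes from liver (Rattus norvegicus) for metabolic stability; a higher number here means that the compound lasts longer, a lower number that the compound disappears faster. Compound 1 `Cn1nc2c(=O)n(CC3(O)CCN(Cc4ccc(-c5ccco5)cc4Cl)CC3)cnc2c1-c1ccc(CNS(C)(=O)=O)cc1` gives 0.433 h, and compound 3 `Cn1nc2c(=O)n(CC3(O)CCN(Cc4ccc(-c5ccco5)cc4Cl)CC3)cnc2c1-c1ccc(CNC=O)cc1` gives 0.55 h; the step of a 1.3-fold higher number from compound 1 to compound 3 (0.10 log units; within the scatter) lies within the scatter. Compound 2 `Cn1nc2c(=O)n(CC3(O)CCN(Cc4ccc(-c5cccs5)cc4Cl)CC3)cnc2c1-c1ccc(CN)cc1` gives 1.38 h, the highest of the three numbers, beyond the scatter from compound 3 and from compound 1. Compound 4 `Cn1nc2c(=O)n(CC3(O)CCN(Cc4ccc(-c5cnco5)cc4Cl)CC3)cnc2c1-c1ccc(CN)cc1` differs from compound 2 by 1,3-oxazol-5-yl in place of thiophen-2-yl on an aromatic carbon. Within the data shown here, no measured step bears directly on this change: the only step known concerns the group on an amine nitrogen, not the five-membered aromatic ring, and it was within the scatter. Compound 4 is therefore expected to show a 1.0-fold higher number from compound 2 to compound 4 (0.01 log units; within the scatter), no step beyond the scatter. Compound 4 is estimated to give 1.4 h, with a range from 0.6 h to 3.2 h.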

Compound 4, half-life: 3.85 h
Beside the measured number, compound 4's estimate is 2.8-fold (0.44 log units) below it; measured number outside the range, above it.
By their numbers in this assay, from the lowest: compounds 1 and 3 (each within the scatter of the next); then compound 2; then compound 4.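

At this place, on an aromatic carbon para to a large group and meta to a chloro group, the choice of five-membered aromatic ring matters in this assay: 1,3-oxazol-5-yl in place of thiophen-2-yl gives a 2.8-fold higher number from compound 2 to compound 4 (0.45 log units; beyond the scatter). Among these compounds, the only earlier step concerned the group on an amine nitrogen, so this step alone reads a change at this ring. Nothing shown accounts for the rise.

On these data alone, it remains open whether the step also holds with a formyl or methylsulfonyl group on the amine nitrogen. As far as these compounds go, how a pyridine or a plain phenyl ring would read at this place also remains open.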